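The source may report more compounds than this note shows. Statements on the series, on what has been measured and on what is new or still open speak of the compounds shown alone.

Measured so far in an ADME assay on cells for inhibition of Intestinal-type alkaline phosphatase (Homo sapiens), read by luminescence, with stated times of 7 min and 20 min; a higher number here means a weaker inhibitor, a lower number a stronger inhibitor:
compound 1 `CCCNc1nn2c(=O)cc(C(F)(F)F)nc2s1` — 310 nM
compound 2 `CCCCNc1nn2c(=O)cc(C(F)(F)F)nc2s1` — 710 nM
compound 3 `CN(C)CCNc1nn2c(=O)cc(C(F)(F)F)nc2s1` — 3750 nM

Compound 2 holds the second highest of the three numbers: compound 1 sits nearest, with a 2.3-fold higher number from compound 1 to compound 2 (0.36 log units; beyond the scatter), and compound 3 sits furthest, with a 5.3-fold higher number from compound 2 to compound 3 (0.72 log units; beyond the scatter). Both measured steps that lengthen or branch the chain on the ring nitrogen move the number upward, the dimethylamino entry more than the methyl one, as a 12-fold higher number from compound 1 to compound 3 (1.08 log units; beyond the scatter) shows.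

Compound 4 `CCCCN(CCCC)c1nn2c(=O)cc(C(F)(F)F)nc2s1` is not yet measured. It differs from compound 2 by butyl in place of hydrogen on a nitrogen on an aromatic ring. Going by the values given here, the change is a butyl in place of hydrogen on a nitrogen on an aromatic ring, so it is the only step in the set that alters the ring nitrogen itself rather than the chain carbons; no measured pair bears on it directly. The chain steps from compound 1 to compound 2 and from compound 2 to compound 3 both went toward higher numbers, and the second butyl is a larger addition than the methyl of compound 2. A step toward a higher number, beyond the scatter, is therefore expected, roughly a 3.1-fold higher number from compound 2 to compound 4 (0.49 log units; beyond the scatter). Compound 4 is estimated at 2200 nM, within 700 nM to 7000 nM.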

Compound 4, half-maximal inhibitory concentration: 4630 nM
Compound 4: the middle estimate sits 2.1-fold (0.32 log units) below what was measured; measured number inside the range.
By their numbers in this assay, from the lowest: compound 1; then compound 2; then compounds 3 and 4 (each within the scatter of the next).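

In this assay, the change at the nitrogen on the aromatic ring itself, butyl in place of hydrogen, gives a 6.5-fold higher number from compound 2 to compound 4 (0.81 log units; beyond the scatter), a step printed as modest, like the chain change in a 5.3-fold higher number from compound 2 to compound 3 (0.72 log units; beyond the scatter). Going by these compounds alone, this is the first reading at this nitrogen, and it shows that the position responds to substitution, yet inhibition is not lost when the hydrogen goes: compound 4 still gives 4630 nM. No measurement shown here accounts for the size of this step or says why the number rises.

Within the data shown here, the single change leaves open whether the rise follows from losing the hydrogen on this nitrogen or from the butyl group that enters, a separation that a methyl or ethyl group on the same nitrogen of compound 2 would help to make. Also open, on these data alone, is how the series reads with the nitrogen held inside a ring amine such as piperidine or morpholine, or with a chain ending in a hydroxyl group or a carboxylic acid.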